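This account rests on a few compounds, and the source may have more. Where it says the series, first, only, none or still open, it means among the compounds named here.

Measured in a physicochemical assay, with a stated time of 6 min; on this read-out higher numbers stand for weaker inhibition and lower numbers for stronger inhibition:
- Compound 1 `O=C(Nc1ccc(Br)cc1)Nc1nc(-c2cc3ccccc3o2)cs1`: > 200000 nM (a limit)
- Compound 2 `O=C(Nc1cccc([N+](=O)[O-])c1)Nc1nc(-c2cc3cc(Br)ccc3o2)cs1`: 159000 nM

Compound 1 has no exact number, only (the limit of > 200000 nM in this assay, at which 1 of the 2 values shown sits). Its true position on the scale is therefore unknown, and any comparison with it stays loose.

Compound 3 `O=C(Nc1cccc(F)c1)Nc1nc(-c2cc3ccccc3o2)cs1` has not yet been measured. It keeps the core of compound 1 but carries 3-fluorophenyl in place of 4-bromophenyl on an amide-type nitrogen.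

For the measured compounds named here, no measured pair of compounds differs in only one place, so the data do not show directly what such a swap does. Going by the values given here, the only guide is compound 2, which gives 159000 nM and so also shows weak inhibition, although it differs from compound 1 in more than one place. On that basis, only a small shift toward stronger inhibition is expected, and the estimated change is an at least 1.3-fold lower number from compound 1 to compound 3 (0.12 log units; that floor lies within the scatter). Compound 3 may also reach the limit of this assay and give no exact number. For compound 3 the expected value is 150000 nM, with an estimated range of 60000 nM to 320000 nM.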

Compound 3, half-maximal inhibitory concentration: 4520 nM
Compound 3: the middle estimate sits 33-fold (1.52 log units) above what was measured, and the stated range ends above it.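

In this assay, swapping 4-bromophenyl for 3-fluorophenyl on an amide-type nitrogen, with the rest of the structure unchanged, gives an at least 44-fold lower number from compound 1 to compound 3 (1.64 log units; beyond the scatter). For the compounds shown here, this is the first direct view of this site, and it shows that inhibition can depend strongly on the group here, even though both groups have the same count of 7 heavy atoms and each has one six-membered aromatic ring of carbon only. The true size of the step remains unknown because compound 1 has a limit rather than an exact number: the limit of > 200000 nM in this assay, at which 1 of the 3 values shown sits.

The swap changes both the halogen and the number in the group's name, so the compounds shown cannot tell which of the two matters; 3-bromophenyl and 4-fluorophenyl would separate them. Also open, as far as these compounds go, is how far this site tolerates other kinds of group, such as plain phenyl, a phenyl ring carrying an amine or a carboxylic acid, or a longer chain in place of the ring.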